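Shifting a Sulfonyl Aryl Group in an Inactive Series

A few compounds are considered here, and "the series" means these few. Any claim that something is new, unique, unknown or untested is made for them only; others in the source may bear on it.

Compound 1 `Cc1ccc(S(=O)(=O)NC2=NCCN2C(=S)SN2CCn3c2nsc3=S)cc1` gives >= 20000 nM in a functional assay on KYSE-510 cells (Homo sapiens) for antiproliferative activity, read by crystal violet staining, with a stated time of 96 h (on this read-out higher numbers stand for weaker inhibition of growth and lower numbers for stronger inhibition of growth), which is a limit of the assay.
Compound 2 `COc1cccc(S(=O)(=O)NC2=NCCN2C(=S)SN2CCn3c2nsc3=S)c1` gives >= 20000 nM in this assay, again a limit.
Compound 3 `COc1ccc(S(=O)(=O)NC2=NCCN2C(=S)SN2CCn3c2nsc3=S)cc1` gives >= 20000 nM in this assay, again a limit.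

Compound 1 thus stands only at a limit, like every other measured compound, as the limit of >= 20000 nM in this assay, at which 3 of the 3 values shown sit, shows. Going by the values given here, the steps a step that the two limits leave unreadable from compound 1 to compound 2, a step that the two limits leave unreadable from compound 1 to compound 3 and a step that the two limits leave unreadable from compound 2 to compound 3 are all unreadable, so no measured step gives a size to carry over. Compound 4 `O=S(=O)(NC1=NCCN1C(=S)SN1CCn2c1nsc2=S)c1ccccc1Cl` differs from compound 1 by 2-chlorophenyl in place of 4-methylphenyl on a sulfonyl sulfur. With every aryl variant so far at the limit, growth inhibition within the measurable window is expected to be unlikely for compound 4, and its step of a number no higher from compound 1 to compound 4 (the limit leaves the size open) is expected to be flat. Compound 4 is estimated at 20000 nM, between 7000 nM and 60000 nM.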

Compound 4, concentration for 50% growth inhibition: >= 20000 nM
Compound 4: a limit, no number; the forecaster's own chance of this, stated with the estimate: 75%; the middle value lies on the limit itself.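

Compound 4 also sits at a limit, so its steps from compound 1, compound 2 and compound 3 cannot be read: the limit of >= 20000 nM in this assay, at which 4 of the 4 values shown sit.

Going by these compounds, how far these compounds lie from measurable growth inhibition in this assay stays open, as does whether their order could differ.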